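Dihydropyridine ester variation: toward a formyloxycarbonyl analogue

The compounds below may be only part of what the source reports. "The series", "measured", "known", "first", "only" and "open" are said of these compounds alone.

Measured compounds:
compound 1 `C=CCOC(=O)C1=C(C)NC(C)=C(C(=O)OCC)C1c1cccc([N+](=O)[O-])c1` — 25 nM
compound 2 `CCOC(=O)C1=C(C)NC(C)=C(C(=O)OCCOC)C1c1cccc([N+](=O)[O-])c1` — 16 nM

Notes on the series. Both measured compounds were tested in a functional assay on HEK293 cells for antagonist activity at Voltage-dependent L-type calcium channel subunit alpha-1C (Oryctolagus cuniculus), read by FLIPR; a lower number here means a stronger inhibitor, a higher number a weaker inhibitor. For the measured compounds named here, compound 2 gives the lowest of the two numbers, with compound 1 as its nearest neighbour; the only measured step, a 1.6-fold lower number from compound 1 to compound 2 (0.19 log units; within the scatter), lies within the scatter, so the two cannot be ranked.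

Compound 3 `CCOC(=O)C1=C(C)NC(C)=C(C(=O)OC=O)C1c1cccc([N+](=O)[O-])c1` is not yet measured. Relative to compound 2 the change is formyl in place of 2-methoxyethyl on an oxygen next to a carbonyl group. Going by the values given here, the one measured step, the change from vinyl to methoxymethyl at the same part of the molecule, left the number essentially unchanged in this assay; it bears on the new step only in showing that this ester position tolerated one alkyl variation. Among the compounds with values here, the move to a formyl group is a different kind of change, and there is no measured step of that kind.

Expectation: compound 3 is estimated to give a somewhat higher number, a 3.8-fold higher number from compound 2 to compound 3 (0.57 log units; beyond the scatter), since no measured step supports equal potency for so small a group at this position. The estimate for compound 3 in this assay is 60 nM, with a range from 15 nM to 250 nM.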

Compound 3, half-maximal inhibitory concentration: 33300 nM
Compound 3: middle estimate off by 560-fold (2.74 log units), on the low side; measured number above the stated range.
By their numbers in this assay, from the lowest: compounds 2 and 1 (each within the scatter of the next); then compound 3.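

In this assay, the substituent on an oxygen next to a carbonyl group proves able to decide the result: formyl in place of 2-methoxyethyl gives a 2100-fold higher number from compound 2 to compound 3 (3.32 log units; beyond the scatter), and formyl in place of allyl gives a 1300-fold higher number from compound 1 to compound 3 (3.12 log units; beyond the scatter). Compounds 1 and 2 could not be ranked and so showed only that two different chains were accepted here, whereas these two large steps show that the tolerance does not extend to every group on this oxygen. Both steps end at the same compound and are of similar size, and compound 3 is the weakest of the three, so the change to formyl, not the choice of starting chain, marks the break in this small set.

Nothing shown gives a measured reason for this jump, so the result stands as an observation only. On these data alone, it remains open whether the jump follows from the formyl group itself or from the shorter substituent, with 2 heavy atoms entering where 2-methoxyethyl has 4, and an acetyl or a methyl group on the same oxygen would help to separate those two readings.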